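The compounds below may be only part of what the source reports. "The series", "measured", "known", "first", "only" and "open" are said of these compounds alone.

Among the measured compounds shown here, compound 1 `CC1(C)S[C@@H]2/C(=C\C(=O)c3ccc(F)cc3)C(=O)N2[C@H]1C(=O)OC(c1ccccc1)c1ccccc1` is one of two compounds measured in a functional assay on NCI-H1299 cells (Homo sapiens) for cytotoxicity, read by MTT assay, with a stated time of 48 h (on this read-out higher numbers stand for weaker inhibition and lower numbers for stronger inhibition), where compound 1 gives 25200 nM. Its companion compound 2 `CC1(C)S[C@@H]2/C(=C\C(=O)OC(c3ccccc3)c3ccccc3)C(=O)N2[C@H]1C(=O)OC(c1ccccc1)c1ccccc1` gives 22400 nM, a number that sits within the usual scatter of that of compound 1. The step to compound 3 `CC(=O)/C=C1/C(=O)N2[C@@H]1SC(C)(C)[C@@H]2C(=O)OC(c1ccccc1)c1ccccc1` changes one place: methyl in place of 4-fluorophenyl on a carbonyl carbon. For the measured compounds named here, no measured pair shows such a change, so the data offer no guide to its size. Compound 3 is expected to move little beyond the scatter, if anything toward weaker inhibition, a step of a 1.3-fold higher number from compound 1 to compound 3 (0.10 log units; within the scatter). The estimate for compound 3 is 32000 nM, within 11000 nM to 95000 nM.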

Compound 3, half-maximal inhibitory concentration: 24200 nM
Compound 3: the middle estimate sits 1.3-fold (0.12 log units) above what was measured; the measured number falls inside the stated range.
By their numbers in this assay, from the lowest: compounds 2, 3 and 1 (each within the scatter of the next).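

In this assay, among the compounds shown here, methyl in place of 4-fluorophenyl on a carbonyl carbon gives a 1.0-fold lower number from compound 1 to compound 3 (0.02 log units; within the scatter) and so offers the first reading at this position. The aromatic ring of the 4-fluorophenyl group can be lost here without the number leaving the scatter. No available evidence accounts for this result.

As far as these compounds go, whether an amine, a carboxylic acid or a longer chain on this carbonyl carbon would also leave the number within the scatter stays open. So does whether any group in this place can move it beyond the scatter at all.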